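The compounds below may be only part of what the source reports. "The series", "measured", "known", "first", "only" and "open" are said of these compounds alone.

Measured compounds:

- compound 1, `O=C(O)CCCCCCCn1nc(-c2ccccc2)c(-c2ccccc2)c1-c1ccccc1`: 3400 nM
- compound 2, `CCc1c(-c2ccccc2)nn(CCCCCCCCC(=O)O)c1-c1ccccc1`: a limit of the assay, > 79000 nM
- compound 3, `O=C(O)CCCCCCn1cc(-c2ccccc2)c(-c2ccccc2)n1`: a limit of the assay, > 92000 nM

Of the compounds shown here, three have been tested in a functional assay for inhibition, with Homo sapiens as the target; a higher number here means a weaker inhibitor, a lower number a stronger inhibitor. Compound 1 gives 3400 nM, and it is the only one of the three for which a number rather than a limit is reported. For compound 2 the assay gives only a limit, > 79000 nM. For compound 3 the assay likewise gives only a limit, > 92000 nM. Among the measured compounds shown here, no two of the measured compounds differ in a single place, so no measured step is available to lean on.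

Compound 4, `CS(=O)(=O)NC(=O)CCCCCCCCn1nc(-c2ccccc2)c(-c2ccccc2)c1-c1ccccc1`, is not yet measured. It differs from compound 1 by ((methylsulfonyl)carbamoyl)methyl in place of carboxy on a saturated chain carbon, seven bonds along the chain from an aromatic nitrogen. Since no measured step of this kind is shown, the expected change in this assay is none beyond the scatter, with the uncertainty left wide on both sides. Compound 4 is therefore expected to give 3500 nM, somewhere between 900 nM and 14000 nM. The expected step is a 1.0-fold higher number from compound 1 to compound 4 (0.01 log units; within the scatter).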

Compound 4, half-maximal inhibitory concentration: 5900 nM
Compound 4: middle estimate off by 1.7-fold (0.23 log units), on the low side; low and high end bracket the measured number.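

In this assay, putting ((methylsulfonyl)carbamoyl)methyl in place of carboxy on a saturated chain carbon, seven bonds along the chain from an aromatic nitrogen, gives a 1.7-fold higher number from compound 1 to compound 4 (0.24 log units; within the scatter), so the two compounds cannot be told apart. The earlier compounds shown here all carry carboxy at the chain end, and compound 4 shows that a measured number in this range does not depend on that group being present on this core. Nothing shown here accounts for this step, and the two limits reported for other compounds do not bear on it.

On these data alone, whether an amine or a methyl ester at the chain end would also keep a measured number remains open. So does whether this same change would behave alike on a shorter chain.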